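This account rests on a few compounds, and the source may have more. Where it says the series, first, only, none or still open, it means among the compounds named here.

Compound 3 `CCCCNC(=O)c1c(NC(=O)NS(=O)(=O)c2ccccc2)sc2c1CCCCC2` stands highest of the two numbers in a functional assay on cells (Cancer cell lines, Homo sapiens) for inhibition, with a stated time of 48 h (a higher number here means a weaker inhibitor of growth, a lower number a stronger inhibitor of growth), where compound 3 gives 85300 nM. Its nearest neighbour, compound 2 `O=C(Nc1sc2c(c1C(=O)NNc1ccccc1)CCCCC2)NS(=O)(=O)c1ccccc1`, gives 30900 nM, a step of a 2.8-fold higher number from compound 2 to compound 3 (0.44 log units; beyond the scatter) for butyl in place of anilino on the amide-type nitrogen. Compound 1 `NNC(=O)c1c(NC(=O)NS(=O)(=O)c2ccccc2)sc2c1CCCCC2` reports only a limit in this assay, namely > 100000 nM. From that limit the step runs to an at least 1.1-fold lower number from compound 1 to compound 3 (0.06 log units; that floor lies within the scatter). Compound 4 `CCCNC(=O)c1c(NC(=O)NS(=O)(=O)c2ccccc2)sc2c1CCCCC2` differs from compound 3 by hydrogen in place of methyl on a saturated chain carbon, three bonds along the chain from an amide-type nitrogen. Neither measured step touches the length of this chain: one swaps amino for butyl, the other anilino for butyl. No step beyond the scatter is expected in this assay, and compound 4 is estimated at 90000 nM, between 40000 nM and 200000 nM, an expected step of a 1.1-fold higher number from compound 3 to compound 4 (0.02 log units; within the scatter).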

Compound 4, concentration for 50% growth inhibition: 72500 nM
Compound 4: middle estimate off by 1.2-fold (0.09 log units), on the high side; measured number inside the range.
By their numbers in this assay, from the lowest: compound 2; then compounds 4 and 3 (each within the scatter of the next). At a limit, above all of these: compound 1.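

Going from butyl to propyl on the amide-type nitrogen leaves the number in this assay within the scatter (a 1.2-fold lower number from compound 3 to compound 4 (0.07 log units; within the scatter)), so removing this methyl gives no readable change. The anilino compound stays apart from the shorter chain too (a 2.3-fold higher number from compound 2 to compound 4 (0.37 log units; beyond the scatter)). The remaining step (an at least 1.3-fold lower number from compound 1 to compound 4 (0.13 log units; that floor lies within the scatter)) cannot be read, because it rests on a limit: the limit of > 100000 nM in this assay, at which 1 of the 4 values shown sits.

Going by these compounds, whether a chain longer than butyl would shift the number remains open. So does whether a benzyl group on that nitrogen would match anilino.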